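From 3-methylthiophen-2-yl to 2,5-dimethoxyphenyl in compound 4

The source may hold more compounds than are shown below. What is called first, only, known or untested is meant among the compounds shown, and "the series" means these compounds.

In a functional assay on DU-145 cells (Homo sapiens) for inhibition, read by trypan blue exclusion, with a stated time of 96 h (on this read-out higher numbers stand for weaker inhibition of growth and lower numbers for stronger inhibition of growth), compound 1 (`Cc1ccsc1/C=C(/SCc1ccc(Cl)c(Cl)c1)C(=O)c1ccc(Cl)cc1`) gives 50000 nM. Compound 3 (`Cc1ccc(S/C(=C/c2sccc2C)C(=O)c2ccc(Cl)cc2)cc1`) gives 50000 nM, level with compound 1, and the two share the highest number of the three. Compound 2 (`Cc1ccsc1/C=C(/SCc1ccc(Cl)cc1Cl)C(=O)c1ccc(Cl)cc1`) gives 10000 nM.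

Compound 4 (`COc1ccc(OC)c(/C=C(/SCc2ccc(Cl)c(Cl)c2)C(=O)c2ccc(Cl)cc2)c1`) carries 2,5-dimethoxyphenyl in place of 3-methylthiophen-2-yl on a double-bonded chain carbon bound to a double-bonded chain carbon.

All measured steps concern the group on a sulfur: a 5.0-fold lower number from compound 1 to compound 2 (0.70 log units; beyond the scatter), no change at the digits printed from compound 1 to compound 3 (within the scatter) and a 5.0-fold higher number from compound 2 to compound 3 (0.70 log units; beyond the scatter). None touches the place changed here, so they only indicate the size of movement seen so far in this assay, and the direction rests on little. With compound 1 at 50000 nM, the top of the numbers seen, a modest move to a lower number is expected, no larger than a 5.0-fold lower number from compound 1 to compound 2 (0.70 log units; beyond the scatter). The expected step is a 2.5-fold lower number from compound 1 to compound 4 (0.40 log units; beyond the scatter). The estimate for compound 4 is 20000 nM, with an expected range of 4000 nM to 80000 nM.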

Compound 4, concentration for 50% growth inhibition: 10000 nM
For compound 4 the middle estimate is 2.0-fold (0.30 log units) above the measured one; low and high end bracket the measured number.
By their numbers in this assay, from the lowest: compounds 2 and 4 (each within the scatter of the next); then compounds 1 and 3 (each within the scatter of the next).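

For the compounds shown here, this is the first step at the place on a double-bonded chain carbon bound to a double-bonded chain carbon, and in this assay it gives a 5.0-fold lower number from compound 1 to compound 4 (0.70 log units; beyond the scatter). The number therefore responds to more than the group on a sulfur, and the one-ring exchange of 3-methylthiophen-2-yl for 2,5-dimethoxyphenyl, with more heavy atoms and an added hydrogen-bond acceptor, is accompanied by stronger inhibition of growth. Nothing measured accounts for this step.

Open, from the compounds shown here alone, is whether the methoxy groups or the carbon-only six-membered ring carries the step, which a plain phenyl or a phenyl bearing an amine or a carboxylic acid at this place would help to separate. Also open, going by these compounds, is whether this change and the 2,4-dichlorobenzyl group on the sulfur add up when combined in one compound.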